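Chloro on the Core: Expected Growth Inhibition for Compound 4

This account rests on a few compounds, and the source may have more. Where it says the series, first, only, none or still open, it means among the compounds named here.

Compound 1 `O=S(=O)(/C=C/c1ccc(Cl)cc1Cl)Cc1ccc(Nc2ncnc3ccccc23)cc1`: 4000 nM
Compound 3 `O=S(=O)(/C=C/c1ccc(Cl)cc1)Cc1ccc(Nc2ncnc3ccc(Br)cc23)cc1`: 30000 nM
Compound 2 `O=S(=O)(/C=C/c1ccc(Cl)c(Cl)c1)Cc1ccc(Nc2ncnc3ccc(Br)cc23)cc1`: > 100000 nM

In a functional assay on U-251 cells (Homo sapiens) (a higher number here means a weaker inhibitor of growth, a lower number a stronger inhibitor of growth), compound 1 gives 4000 nM, the lowest of the two numbers measured. Compound 3 gives 30000 nM. For compound 2 the value is a limit of this assay, not a number (the limit of > 100000 nM in this assay, at which 1 of the 3 values shown sits). The difference between the core of compound 1 and the core of compound 3 is not broken down here.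

From compound 3 to compound 2 the change is chloro in place of hydrogen on an aromatic carbon, and it gave an at least 3.3-fold higher number from compound 3 to compound 2 (0.52 log units; beyond the scatter). Compound 4 `O=S(=O)(/C=C/c1ccc(Cl)cc1Cl)Cc1ccc(Nc2ncnc3cc(Cl)ccc23)cc1` is not yet measured. Its change from compound 1 is chloro in place of hydrogen on an aromatic carbon, the same kind of change but at a different place: it sits on a ring that is part of a fused or bridged system of two rings, meta to a fused ring and para to a fused ring, rather than ortho to a chloro group and meta to a large group.

Because the earlier step was an at least 3.3-fold higher number from compound 3 to compound 2 (0.52 log units; beyond the scatter), a weakening is expected for compound 4, but a smaller one given the different place, and the estimate is 8000 nM, spanning 2000 nM to 40000 nM, which means an expected step of a 2.0-fold higher number from compound 1 to compound 4 (0.30 log units; within the scatter).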

Compound 4, concentration for 50% growth inhibition: 53000 nM
For compound 4 the middle estimate is 6.6-fold (0.82 log units) below the measured one; the whole stated range lies below it.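

In this assay, putting chloro in place of hydrogen on an aromatic carbon of the core gave a 13-fold higher number from compound 1 to compound 4 (1.12 log units; beyond the scatter), a large step towards weaker inhibition of growth. Set beside the earlier step, the same change moved the number in the same direction on both cores, although it sits at a different place in each: the same change on two cores in this assay, an at least 3.3-fold higher number (0.52 log units; beyond the scatter) from compound 3 to compound 2 and a 13-fold higher number (1.12 log units; beyond the scatter) from compound 1 to compound 4; the limit leaves it open whether they differ

This shows that the direction held in these two pairs, but the earlier step ends at a limit of the assay rather than a number, so it does not show that the size of the effect carries from one core to another, and two pairs make no rule for the series.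

The compounds shown leave open whether chloro at other places on the core of compound 1 would give a similar step. They also leave open whether a different group at this same place, such as fluoro, methoxy or an amine, would raise the number as well.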